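The source may hold more compounds than are shown below. What is called first, only, known or untested is meant among the compounds shown, and "the series" means these compounds.

Two compounds share one core and differ only at the ring attached to the amide nitrogen. Compound 1 `Cc1cccc(NC(=O)CSc2nnc(-c3ccoc3C)n2Cc2ccco2)c1C` carries a dimethylphenyl group there, and in a functional assay on CHO cells for antagonist activity at Orexin/Hypocretin receptor type 1 (Homo sapiens), read by FLIPR and calcium flux (on this read-out lower numbers stand for stronger inhibition and higher numbers for weaker inhibition), compound 1 is recorded only as a limit, > 15800 nM, rather than as a number; this is the limit of > 15800 nM in this assay, at which 1 of the 2 values shown sits. Among the compounds with values here, compound 2 `Cc1cccc(NC(=O)CSc2nnc(-c3ccoc3C)n2Cc2ccco2)c1` keeps a single methyl on that ring, and in this assay compound 2 gives 2510 nM, the only full number among the two values shown. Within the data shown here, the change an at least 6.2-fold lower number from compound 1 to compound 2 (0.79 log units; beyond the scatter) is the one measured step here.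

Compound 3 `Cc1occc1-c1nnc(SCC(=O)Nc2ccc(Cl)cc2)n1Cc1ccco1` is the next member: 4-chlorophenyl in place of 3-methylphenyl on an amide-type nitrogen. The measured step removed a methyl from that ring, while here the remaining methyl is traded for a chlorine at a different place on the ring, so the earlier step is only a loose guide. Among the measured compounds shown here, with no closer precedent, the expectation is a change no larger than the scatter, and compound 3 is estimated at 3000 nM (range 800 nM to 12000 nM), an expected step of a 1.2-fold higher number from compound 2 to compound 3 (0.08 log units; within the scatter).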

Compound 3, inhibition constant: 2000 nM
Beside the measured number, compound 3's estimate is 1.5-fold (0.18 log units) above it; low and high end bracket the measured number.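

In this assay, trading 3-methylphenyl for 4-chlorophenyl on the amide-type nitrogen gives a 1.3-fold lower number from compound 2 to compound 3 (0.10 log units; within the scatter), so this position accepts a ring with a chlorine as well as one with a methyl, with no difference that can be told from the scatter. Set against the 2,3-dimethylphenyl ring, the same group gives an at least 7.9-fold lower number from compound 1 to compound 3 (0.89 log units; beyond the scatter), so two different rings with a single substituent now both stand clear of the ring with two methyl groups. Compound 1 is still a limit and not a number, so the true size of both steps from it stays unknown: the limit of > 15800 nM in this assay, at which 1 of the 3 values shown sits.

Because compound 2 and compound 3 differ in both the group on the ring and its place, the compounds shown leave open whether either factor matters on its own, a question that 4-methylphenyl or 3-chlorophenyl would address. They also leave open how a plain phenyl ring with no substituent would read here, or one carrying an amine or a carboxylic acid.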